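The source may hold more compounds than are shown below. What is called first, only, known or untested is meant among the compounds shown, and "the series" means these compounds.

In a functional assay on SMMC-7721 cells (Homo sapiens) for cytotoxicity, read by MTT assay, with a stated time of 4 days (a lower number here means a stronger inhibitor, a higher number a weaker inhibitor), compound 1, whose structure is `C=C1C(=O)[C@]23C[C@@]1(O)CC[C@H]2c1ccc(OS(=O)(=O)c2ccc(C)cc2)c(C)c1[C@@H]3Cn1cc(-c2ccc(Br)cc2)nn1`, gives 4320 nM, the lowest of the two numbers recorded there. Its closest companion is compound 3, `C=C1C(=O)[C@]23C[C@@]1(O)CC[C@H]2c1ccc(OS(=O)(=O)c2ccc(C)cc2)c(C)c1[C@@H]3Cn1cc(-c2ccc(C)cc2)nn1`, which gives 4410 nM; the step of a 1.0-fold higher number from compound 1 to compound 3 (0.01 log units; within the scatter) is a methyl in place of bromo on an aromatic carbon and stays within the scatter. Compound 2, `Cc1ccc(S(=O)(=O)Oc2ccc3c(c2C)[C@H](Cn2cc(-c4ccc(Cl)cc4)nn2)[C@@]24CC(=O)[C@@](C)(CC[C@@H]32)C4)cc1`, reaches only a limit of this assay, > 20000 nM. That limit is described by the limit of > 20000 nM in this assay, at which 1 of the 3 values shown sits.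

Compound 4, `C=C1C(=O)[C@]23C[C@@]1(O)CC[C@H]2c1ccc(O)c(C)c1[C@@H]3Cn1cc(-c2ccc(Br)cc2)nn1`, is compound 1 with hydrogen in place of (4-methylphenyl)sulfonyl on an oxygen on an aromatic ring: the ((4-methylphenyl)sulfonyl)oxy group becomes hydroxy. Among the compounds with values here, no measured step touches this oxygen. Within the data shown here, the one step that has been measured, from compound 1 to compound 3, changes a group on a distant aromatic ring and is within the scatter, so it gives no lead on the size or direction of the present change. The expectation for compound 4 is therefore anchored on compound 1 alone, with a wide range: the step of a 1.0-fold higher number from compound 1 to compound 4 (0.02 log units; within the scatter) is estimated to be small, without a preferred direction. Compound 4 is expected to give about 4500 nM in this assay, with a plausible range from 1200 nM to 17000 nM.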

Compound 4, half-maximal inhibitory concentration: 1300 nM
For compound 4 the middle estimate is 3.5-fold (0.54 log units) above the measured one; measured number inside the range.
By their numbers in this assay, from the lowest: compound 4; then compounds 1 and 3 (each within the scatter of the next). At a limit, above all of these: compound 2.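

In this assay, within the data shown here, the change at this oxygen has a clear effect, a 3.3-fold lower number from compound 1 to compound 4 (0.52 log units; beyond the scatter), whereas the only earlier step, a 1.0-fold higher number from compound 1 to compound 3 (0.01 log units; within the scatter), lies within the scatter and concerned a different part of the molecule. The result therefore shows that this position on the shared core responds to substitution, and that replacing the ((4-methylphenyl)sulfonyl)oxy group with hydroxy gives a modest gain rather than a loss of activity, so the (4-methylphenyl)sulfonyl group is not required for cytotoxicity here. Nothing measured among these compounds accounts for why the number falls with this change.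

The compounds shown leave open how other groups on this oxygen would behave, such as a methyl ether, an acetate ester or a methanesulfonyl group, and so whether the gain belongs to the free hydroxy itself or simply follows the loss of the (4-methylphenyl)sulfonyl group. They also leave open whether the same step would hold when methyl stands in place of bromo on the aromatic carbon, as it does in compound 3.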